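Indanyl in Place of Acetamidobenzyl on the Amine Nitrogen

The source may report more compounds than this note shows. Statements on the series, on what has been measured and on what is new or still open speak of the compounds shown alone.

Compound 1, `CN(Cc1ccsc1)C1CCN(CCCc2c[nH]c3ccc(-n4cnnc4)cc23)CC1`: 1.5 nM
Compound 2, `CC(=O)Nc1ccc(CNCC2CCN(CCCc3c[nH]c4ccc(-n5cnnc5)cc34)CC2)cc1`: 4.2 nM

Both measured compounds were tested in an assay on CHO cells for displacement of a labelled ligand from 5-hydroxytryptamine receptor 1D (Homo sapiens); on this read-out higher numbers stand for weaker inhibition and lower numbers for stronger inhibition. Going by the values given here, compound 2 holds the higher of the two numbers; its only neighbour, compound 1, gives 1.5 nM, a gap beyond the usual scatter. Compound 3, `c1ccc2c(c1)CCC2NCC1CCN(CCCc2c[nH]c3ccc(-n4cnnc4)cc23)CC1`, is not yet measured and differs from compound 2 in one place: 2,3-dihydro-1H-inden-1-yl in place of 4-acetamidobenzyl on an amine nitrogen. Among the compounds with values here, no measured pair shows this change, so the expectation rests on compound 2 alone, which gives 4.2 nM in this assay. The step expected in this assay is a 1.1-fold lower number from compound 2 to compound 3 (0.02 log units; within the scatter), none beyond the scatter. Compound 3 is therefore estimated at 4 nM, within a range from 1 nM to 15 nM.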

Compound 3, half-maximal inhibitory concentration: 1.1 nM
Beside the measured number, compound 3's estimate is 3.6-fold (0.56 log units) above it; measured number inside the range.
By their numbers in this assay, from the lowest: compounds 3 and 1 (each within the scatter of the next); then compound 2.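

In this assay, the amine nitrogen position accepts a carbon-only 2,3-dihydro-1H-inden-1-yl group in place of 4-acetamidobenzyl, with a 3.8-fold lower number from compound 2 to compound 3 (0.58 log units; beyond the scatter) showing that the hydrogen-bond donor and acceptor of the leaving group are not required for strong inhibition. The other change, ((2,3-dihydro-1H-inden-1-yl)amino)methyl in place of methyl((thiophen-3-yl)methyl)amino on a saturated ring carbon, gives a 1.4-fold lower number from compound 1 to compound 3 (0.13 log units; within the scatter) and so separates neither compound from the other. Nothing available explains the step from the 4-acetamidobenzyl compound.

From the compounds shown here alone, whether the five-membered ring matters remains open. A plain benzyl group or a cyclohexyl group on the same amine nitrogen would bear on this.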